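Urea aryl swap on compound 2: working notes

The source may report more compounds than this note shows. Statements on the series, on what has been measured and on what is new or still open speak of the compounds shown alone.

Compound 1 `CNC(=O)Nc1ccc(-c2nc(N3CC4CCC(C3)O4)c3cnn(C(C)C)c3n2)cc1`: 5 nM
Compound 2 `O=C(Nc1ccccc1)Nc1ccc(-c2nc(N3CC4CCC(C3)O4)c3cnn(C4CCC5(CC4)OCCO5)c3n2)cc1`: 4 nM

Both values come from a functional assay on LNCaP cells (Homo sapiens) for cytotoxicity; a higher number here means a weaker inhibitor, a lower number a stronger inhibitor. Compound 2, at 4 nM, lies within the usual scatter of compound 1, at 5 nM, so the two numbers cannot be separated and neither compound can be ranked over the other. Both sit in the low end of the range this read-out can usefully compare.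

The next compound to be read is compound 3 `O=C(Nc1ccncc1)Nc1ccc(-c2nc(N3CC4CCC(C3)O4)c3cnn(C4CCC5(CC4)OCCO5)c3n2)cc1`. It carries pyridin-4-yl in place of phenyl on an amide-type nitrogen, and the rest of compound 2 is kept: pyridin-4-yl in place of phenyl on an amide-type nitrogen.

For the measured compounds named here, no measured pair isolates this change, so its size in this assay has no direct precedent here. Going by the values given here, the only anchor is compound 2 at 4 nM. No step beyond the scatter is expected, and no direction can be argued with any confidence. The expected step, no change at the digits printed from compound 2 to compound 3 (within the scatter), is therefore small. For compound 3 the estimated value is 4 nM, with an expected range of 1.5 nM to 12 nM.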

Compound 3, half-maximal inhibitory concentration: 1 nM
Compound 3: the middle estimate sits 4.0-fold (0.60 log units) above what was measured, and the stated range ends above it.
By their numbers in this assay, from the lowest: compound 3; then compounds 2 and 1 (each within the scatter of the next).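

Replacing phenyl with pyridin-4-yl on the amide-type nitrogen gives the first difference in this series that can be read as a step: in this assay the result is a 4.0-fold lower number from compound 2 to compound 3 (0.60 log units; beyond the scatter) and it lies beyond the scatter, whereas the earlier values could not be separated. The substituent on this nitrogen is therefore not a silent part of the structure, as a swap that keeps 6 heavy atoms but brings in a ring nitrogen and a hydrogen-bond acceptor is enough to move the read-out. No measurement here bears on why the number falls, so the step stands as an observation without an explanation.

This is one matched pair in one assay, so it cannot show whether the step belongs to pyridin-4-yl specifically or to a ring nitrogen more generally; pyridin-3-yl, pyridin-2-yl or pyrimidin-5-yl on the same nitrogen would separate those readings. For the compounds shown here, also open is whether the step persists when the group on the far side of the shared core is something other than the one carried by compound 2 and compound 3, such as a simple isopropyl group.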